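Tetrahydroisoquinoline for methylpiperidine on the chain carbon

The source may hold more compounds than are shown below. What is called first, only, known or untested is meant among the compounds shown, and "the series" means these compounds.

Measured so far:
compound 1 `COc1ccc2[nH]c(C(=O)N3CC(=O)N(Cc4ccccc4)[C@@H](CN4CCC(C)CC4)C3)cc2c1` — 0.267 h
compound 2 `COc1ccc2[nH]c(C(=O)N3CC(=O)N(Cc4ccc[nH]4)[C@@H](Cc4ccccc4)C3)cc2c1` — 0.267 h
compound 3 `COc1ccc2[nH]c(C(=O)N3CC(=O)N(Cc4cccc(OC(F)F)c4)[C@@H](CN4CCCCC4)C3)cc2c1` — 0.317 h

All three numbers come from an ADME assay on microsomes from liver (Homo sapiens) for metabolic stability, with a stated time of 30 min, tested at 1 uM; on this read-out lower numbers stand for a shorter-lived compound and higher numbers for a longer-lived compound. Compound 1 stands level with compound 2 at the digits shown, and together these two are the lowest of the three numbers; compound 3 reads a little higher, but that gap lies within the scatter, so no ordering among the three is claimed. Compounds 2 and 3 differ from compound 1 at more than one place, so their values say only that they sit close to compound 1 in this assay.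

Compound 4 `COc1ccc2[nH]c(C(=O)N3CC(=O)N(Cc4ccccc4)[C@@H](CN4CCc5ccccc5C4)C3)cc2c1` has not yet been measured. It differs from compound 1 in one place: 1,2,3,4-tetrahydroisoquinolin-2-yl in place of 4-methylpiperidin-1-yl on a saturated chain carbon bound to a saturated ring carbon. For the measured compounds named here, no step between measured compounds touches this part of the molecule, so nothing measured here bears directly on the change. For this assay the step of a 1.1-fold lower number from compound 1 to compound 4 (0.03 log units; within the scatter) is expected to be small, with no clear direction and not beyond the scatter, since all three measured values cluster together. Compound 4 is expected to give 0.25 h in this assay, with the estimate spanning 0.12 h to 0.5 h.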

Compound 4, half-life: 0.617 h
Beside the measured number, compound 4's estimate is 2.5-fold (0.39 log units) below it; the whole stated range lies below it.
By their numbers in this assay, from the lowest: compounds 1, 2, 3 and 4 (each within the scatter of the next, the first and the last beyond it).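

In this assay, for the compounds shown here, 1,2,3,4-tetrahydroisoquinolin-2-yl in place of 4-methylpiperidin-1-yl on a saturated chain carbon bound to a saturated ring carbon gives a 2.3-fold higher number from compound 1 to compound 4 (0.36 log units; beyond the scatter) and is the only single-place step available in this set. Going by these compounds alone, the position is therefore not silent: with the rest of the molecule held constant, the group here moves the half-life beyond the scatter, something the earlier compounds could not show because they differ from compound 1 at more than one place. The entering group brings a six-membered aromatic ring of carbon only and leaves the counts of hydrogen-bond donors and acceptors and the net charge as they were, but no measurement at hand explains the step.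

From the compounds shown here alone, it remains open whether the aromatic ring itself goes with the higher number, which 4-phenylpiperidin-1-yl or morpholin-4-yl on the same chain carbon would help to test. Also open, going by these compounds, is whether the step carries over to compounds that differ elsewhere, such as one with the difluoromethoxy group of compound 3.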